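A few compounds are considered here, and "the series" means these few. Any claim that something is new, unique, unknown or untested is made for them only; others in the source may bear on it.

Measured compounds:
compound 1, `CC1(C)CC12NC(=O)N(NC(=O)c1ccc(Cl)cc1)C2=O`: 100 mg/kg
compound 2, `CC1(C)CC12NC(=O)N(NC(=O)c1ccc(Br)cc1)C2=O`: 300 mg/kg

The study works on a shared core and varies the aryl group attached to the carbonyl carbon of the acyl hydrazide. In a functional assay on the whole organism (Hindlimb) for inhibition, with Mus musculus as the target, with a stated time of 0.5 h (on this read-out higher numbers stand for an effect only at larger amounts of compound and lower numbers for an effect already at smaller amounts), compound 1 gives 100 mg/kg, while compound 2 gives 300 mg/kg. Among the compounds with values here, the single measured step, a 3.0-fold higher number from compound 1 to compound 2 (0.48 log units; beyond the scatter), is the exchange of bromo for chloro on an aromatic carbon. Within the data shown here, compound 2 therefore stands at the higher of the two numbers, with compound 1 as its only neighbour.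

The unmeasured compound 3, `CC1(C)CC12NC(=O)N(NC(=O)c1ccccc1F)C2=O`, differs from compound 2 as follows: 2-fluorophenyl in place of 4-bromophenyl on a carbonyl carbon. Among the measured compounds shown here, both the halogen and its place on the ring change at once, so no measured step bears directly on this move; the step from compound 1 to compound 2 only shows that a change of halogen on the ring can shift this assay by a modest amount. Compound 3 is thus expected to give 150 mg/kg, within 50 mg/kg to 500 mg/kg, which means an expected step of a 2.0-fold lower number from compound 2 to compound 3 (0.30 log units; within the scatter), a modest lowering that may well stay within the scatter.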

Compound 3, minimum effective dose: 100 mg/kg
Beside the measured number, compound 3's estimate is 1.5-fold (0.18 log units) above it; the range from low to high includes it.
By their numbers in this assay, from the lowest: compounds 1 and 3 (each within the scatter of the next); then compound 2.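

In this assay, the exchange of 4-bromophenyl for 2-fluorophenyl on the carbonyl carbon gives a 3.0-fold lower number from compound 2 to compound 3 (0.48 log units; beyond the scatter) and so shows that the number at this position can come back down after the rise seen with the bromo compound. Set against the 4-chlorophenyl group, the same 2-fluorophenyl group gives no change at the digits printed from compound 1 to compound 3 (within the scatter), so a different halogen at a different place on the ring leaves the number where it was, and these two aryl groups cannot be told apart in this read-out. Among the three compounds, compound 2 alone stands apart, with compounds 1 and 3 sharing the same printed value. No measurement shown here offers an explanation for these steps.

Since compound 3 changes both the halogen and its place on the ring at once, the three compounds leave open how much of its step from compound 2 belongs to each of those two changes. They also leave open how this assay responds to an aryl group bearing no halogen at all, such as plain phenyl, or one carrying a methoxy group or an amine.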